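Removing the 1,1-dimethylpropoxy group from compound 3

A few compounds are considered here, and "the series" means these few. Any claim that something is new, unique, unknown or untested is made for them only; others in the source may bear on it.

Compound 1 `O=C1NC(=O)C(Cc2ccc(OCC3CCCCC3)cc2)S1`: 26000 nM
Compound 2 `O=C1NC(=O)/C(=C/c2ccc(OCC3CCC3)cc2)S1`: 13000 nM
Compound 3 `CCC(C)(C)Oc1ccc(CC2SC(=O)NC2=O)cc1`: 23000 nM

In a functional assay on PC-12 cells (Rattus norvegicus) for inhibition, read by sulforhodamine B assay (on this read-out lower numbers stand for stronger inhibition and higher numbers for weaker inhibition), compound 3 stands second highest of the three numbers, within the scatter of both compound 1 and compound 2. Compound 4 `O=C1NC(=O)C(Cc2ccccc2)S1` has hydrogen in place of 1,1-dimethylpropoxy on an aromatic carbon, and hydrogen in place of 1,1-dimethylpropoxy on an aromatic carbon gives the count. Among the compounds with values here, one measured step bears on this: a 1.1-fold lower number from compound 1 to compound 3 (0.05 log units; within the scatter) exchanges one group on the oxygen for another and stays within the scatter. Within the data shown here, no measured compound lacks that oxygen substituent, so the step guides removal only weakly. A modest 2.2-fold higher number from compound 3 to compound 4 (0.34 log units; beyond the scatter) is expected, towards weaker inhibition. For compound 4 the estimate is 50000 nM, with an expected range from 20000 nM to 120000 nM in this assay.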

Compound 4, half-maximal inhibitory concentration: > 100000 nM
Compound 4 gave a limit, no number; the forecaster's own chance of this, stated with the estimate: 30%; middle value at least 2.0-fold (0.30 log units) away from the limit.
By their numbers in this assay, from the lowest: compounds 2, 3 and 1 (each within the scatter of the next). At a limit, above all of these: compound 4.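

In this assay, hydrogen in place of 1,1-dimethylpropoxy gives an at least 4.3-fold higher number from compound 3 to compound 4 (0.63 log units; beyond the scatter), the only step in the series shown that lies beyond the scatter. Within the data shown here, the exchange on the oxygen, a 1.1-fold lower number from compound 1 to compound 3 (0.05 log units; within the scatter), compared only two groups there; the new step shows that losing the whole substituent from this aromatic carbon moves the read-out towards weaker inhibition. Compound 4 stands at a limit and not at a number: the limit of > 100000 nM in this assay, at which 1 of the 4 values shown sits.

As far as these compounds go, whether the oxygen alone or the carbon group on it carries this difference stays open; a hydroxyl or a methoxy group in this place would separate the two. From the compounds shown here alone, how an amine or a carboxylic acid at this carbon would read also remains open.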